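Cyclopropylamino to isobutylsulfanyl at the same aromatic carbon

A few compounds are considered here, and "the series" means these few. Any claim that something is new, unique, unknown or untested is made for them only; others in the source may bear on it.

Measured so far in an ADME assay on HFF cells (Homo sapiens) for cytotoxicity, with a stated time of 8 days; a higher number here means that more compound is tolerated, a lower number that less compound is tolerated:
Compound 1, `CCCCSc1nc(N)nc2c1ncn2/C=C1/CC1(CO)CO`, gives > 300000 nM; this value is a limit of the assay, not a number.
Compound 2, `Nc1nc(NC2CCCCC2)c2ncn(/C=C3/CC3(CO)CO)c2n1`, gives > 300000 nM; again a limit of the assay.
Compound 3, `Nc1nc(NC2CC2)c2ncn(/C=C3/CC3(CO)CO)c2n1`, gives > 300000 nM; again a limit of the assay.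

Compound 3 thus stands nowhere distinguishable from its two neighbours: only a limit is known for it, and the two further values shown are limits as well, so that the limit of > 300000 nM in this assay, at which 3 of the 3 values shown sit, describes the whole set. The step to compound 4, `CC(C)CSc1nc(N)nc2c1ncn2/C=C1/CC1(CO)CO`, is isobutylsulfanyl in place of cyclopropylamino on an aromatic carbon.

Within the data shown here, two measured steps touch the same aromatic carbon. From a butylsulfanyl compound the step that the two limits leave unreadable from compound 1 to compound 3 is unreadable, and from a cyclohexylamino compound the step that the two limits leave unreadable from compound 2 to compound 3 is unreadable, both because the limit of > 300000 nM in this assay, at which 3 of the 3 values shown sit, covers every value involved; the same holds for a step that the two limits leave unreadable from compound 1 to compound 2. The change to compound 4 brings back a sulfanyl chain of the kind carried by compound 1, which itself sits at the limit. No readable step in this assay is therefore expected from compound 3 to compound 4; the estimated step is a number no higher from compound 3 to compound 4 (the limit leaves the size open). Compound 4 is expected to give 300000 nM, within a range from 150000 nM to 600000 nM, most likely reported again only as a limit.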

Compound 4, half-maximal cytotoxic concentration: > 300000 nM
Compound 4: no number, only a limit (the forecaster's own chance of this, stated with the estimate: 85%); the middle value sits exactly at the limit.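

The steps from compound 1, compound 2 and compound 3 to compound 4 cannot be read, as all four compounds share one limit: the limit of > 300000 nM in this assay, at which 4 of the 4 values shown sit.

The compounds shown leave open at what concentration any of them becomes cytotoxic in this assay, and whether the butylsulfanyl, isobutylsulfanyl, cyclohexylamino and cyclopropylamino groups differ there at all.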